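Chloro to ethoxy on the dichloropyridine urea

The source may report more compounds than this note shows. Statements on the series, on what has been measured and on what is new or still open speak of the compounds shown alone.

Compound 1, `CCOc1nc(Cl)cc2nc(NCc3cc(C)c(-c4cn(C)nc4C)cn3)[nH]c12`, in a functional assay on HFL1 cells for antagonist activity at sphingosine 1-phosphate receptor 2 (Homo sapiens), read by ELISA, with a stated time of 24 h, in the absence of a further agent (on this read-out lower numbers stand for stronger inhibition and higher numbers for weaker inhibition), gives 2.25 nM.
Compound 2, `Cc1cc(CNC(=O)c2cc(Cl)nc(Cl)c2)ncc1-c1cn(C)nc1C`, in this assay gives > 100 nM, which is a limit of the assay and not a number.
Compound 3, `Cc1cc(CNC(=O)Nc2cc(Cl)nc(Cl)c2)ncc1-c1cn(C)nc1C`, in this assay gives 0.77 nM.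

Compound 3 stands lowest of the two numbers; compound 1 is the nearest, with a higher number beyond the scatter. Among the measured compounds shown here, the one measured step, an at least 120-fold lower number from compound 2 to compound 3 (2.11 log units; beyond the scatter), concerns the linker, not the substituents of the dichloropyridine; the fact that one of the three values is a limit, (the limit of > 100 nM in this assay, at which 1 of the 3 values shown sits), bears on that step.

Compound 4, `CCOc1cc(NC(=O)NCc2cc(C)c(-c3cn(C)nc3C)cn2)cc(Cl)n1`, differs from compound 3 by ethoxy in place of chloro on an aromatic carbon, on an aromatic carbon of a six-membered aromatic ring with one nitrogen, next to the ring nitrogen, meta to a chloro group and meta to a large group. For the measured compounds named here, no measured step changes a chloro to an ethoxy on this ring; the values of compound 1, which carries an ethoxy and one chloro on its own core, and of compound 3 show only that both lie at the low end of the series, with no shared scaffold to compare them on. Going by the values given here, with no direct precedent, a step within the scatter is expected, a 1.9-fold higher number from compound 3 to compound 4 (0.29 log units; within the scatter), in either direction. Compound 4 is therefore expected to give 1.5 nM, in the range 0.4 nM to 6 nM, in this assay.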

Compound 4, half-maximal inhibitory concentration: 0.032 nM
Compound 4: the middle estimate sits 47-fold (1.67 log units) above what was measured; measured number outside the range, below it.
By their numbers in this assay, from the lowest: compound 4; then compound 3; then compound 1. At a limit, above all of these: compound 2.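

Ethoxy in place of chloro on an aromatic carbon next to the ring nitrogen gives, in this assay, a 24-fold lower number from compound 3 to compound 4 (1.38 log units; beyond the scatter), so this position of the six-membered aromatic ring with 1 nitrogen responds strongly to its substituent. The earlier steps shown here concerned only the linker and said nothing about this ring, whereas this step shows that the urea series accepts a group of 3 heavy atoms here in place of a single chlorine, and that the number falls beyond the scatter when it does. Nothing measured here accounts for the size of this step, and the one limit in the series has no bearing on it.

On these data alone, whether the fall belongs to ethoxy in particular stays open, since a single replacement cannot separate the ring oxygen link from the chain it carries; methoxy, a longer chain such as propoxy, or an amine at this position would draw that line. Also open, as far as these compounds go, is what the remaining chloro contributes, and whether ethoxy there, or a second ethoxy on the same ring, would move the number in the same direction.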